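A Cyclopropyl Group on the Amine of Compound 3

The source may hold more compounds than are shown below. What is called first, only, known or untested is meant among the compounds shown, and "the series" means these compounds.

Of the compounds shown here, three sharing one core have been tested in a functional assay on the whole organism with Rattus norvegicus as the target, in the maximal electroshock model; on this read-out higher numbers stand for an effect only at larger amounts of compound and lower numbers for an effect already at smaller amounts. Compound 3, with the structure `Nc1ncnc2c1ncn2Cc1ccccc1F`, gives 4.5 mg/kg in this assay. Compound 1, with the structure `CN(c1ncnc2c1ncn2Cc1ccccc1F)C1CC1`, gives 6.8 mg/kg in this assay, and the step of a 1.5-fold lower number from compound 1 to compound 3 (0.18 log units; within the scatter) lies within the scatter. Compound 2, with the structure `Fc1ccccc1Cn1cnc2c(N3CCC3)ncnc21`, reaches only a limit of the assay, > 50 mg/kg, in this assay. Because of that limit of > 50 mg/kg in this assay, at which 1 of the 3 values shown sits, the step of an at least 11-fold lower number from compound 2 to compound 3 (1.04 log units; beyond the scatter) is reported as large.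

Compound 4, with the structure `Fc1ccccc1Cn1cnc2c(NC3CC3)ncnc21`, has not yet been measured. It differs from compound 3 by cyclopropyl in place of hydrogen on a nitrogen on an aromatic ring. Both measured steps bear on this change: one puts a cyclopropyl and a methyl on the same nitrogen and stays within the scatter, the other closes that nitrogen into azetidin-1-yl and moves beyond the scatter. Compound 4 keeps one hydrogen on the nitrogen and adds only the cyclopropyl, which is closer to the change that stayed within the scatter, so the expected step of a 1.2-fold higher number from compound 3 to compound 4 (0.09 log units; within the scatter) is small, within the scatter. For compound 4 the estimated value in this assay is 5.5 mg/kg, expected to fall between 2.5 mg/kg and 14 mg/kg.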

Compound 4, dose for half-maximal effect: 5 mg/kg
The estimate for compound 4 lay 1.1-fold (0.04 log units) above the measured number, and the stated range covers the measured number.
By their numbers in this assay, from the lowest: compounds 3, 4 and 1 (each within the scatter of the next). At a limit, above all of these: compound 2.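

In this assay, the step of a 1.1-fold higher number from compound 3 to compound 4 (0.05 log units; within the scatter) shows that a cyclopropyl on this nitrogen, with one hydrogen kept there, leaves the read-out within the scatter, and the step of a 1.4-fold lower number from compound 1 to compound 4 (0.13 log units; within the scatter) shows the same for adding a methyl to that nitrogen. On this read-out, amino, cyclopropylamino and cyclopropyl(methyl)amino therefore cannot be told apart, while azetidin-1-yl stands apart from them, as the step of an at least 10-fold lower number from compound 2 to compound 4 (1.00 log units; beyond the scatter) shows. That step is a bound and not a measured size because compound 2 sits at a limit of the assay: the limit of > 50 mg/kg in this assay, at which 1 of the 4 values shown sits.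

The compounds shown leave open whether a cyclobutyl or an open chain such as ethyl or propyl on this nitrogen would also stay within the scatter. They also leave open whether a larger closed ring on the same aromatic carbon, such as pyrrolidin-1-yl or piperidin-1-yl, would give a number like those of compound 3 and compound 4 or would go the way of azetidin-1-yl.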